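Swapping the furan arm for 4-isopropylphenyl

The compounds below may be only part of what the source reports. "The series", "measured", "known", "first", "only" and "open" are said of these compounds alone.

In a functional assay on MCF7 cells (Homo sapiens) for inhibition, read by CCK-8 assay, with a stated time of 48 h (on this read-out higher numbers stand for weaker inhibition of growth and lower numbers for stronger inhibition of growth), compound 3 `CN1CCN(c2ccc(Nc3ncc(Cl)c(NCc4ccco4)n3)nc2)CC1` gives 21300 nM, and compound 1 `COc1cccc(CNc2nc(Nc3ccc(N4CCN(C)CC4)cn3)ncc2Cl)c1` gives 19500 nM, so the two stand level within the scatter. Compound 2 `COc1ccccc1CNc1nc(Nc2ccc(N3CCN(C)CC3)cn2)ncc1Cl` gives only a limit of the assay, > 100000 nM.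

Compound 4 `CC(C)c1ccc(Nc2nc(Nc3ccc(N4CCN(C)CC4)cn3)ncc2Cl)cc1` carries 4-isopropylphenyl in place of (furan-2-yl)methyl on a nitrogen on an aromatic ring. The measured steps all keep a saturated chain carbon on that nitrogen, so they bear on this change only indirectly. Furan-2-yl in place of 3-methoxyphenyl made little difference, with a 1.1-fold higher number from compound 1 to compound 3 (0.04 log units; within the scatter). Yet 2-methoxyphenyl in place of 3-methoxyphenyl gave an at least 5.1-fold higher number from compound 1 to compound 2 (0.70 log units; beyond the scatter), so a change here can matter.

With no firm direction to go on, no step beyond the scatter is expected in this assay, and the expected result is a 1.3-fold lower number from compound 3 to compound 4 (0.10 log units; within the scatter). Compound 4 is estimated at 17000 nM, with an expected range of 4000 nM to 70000 nM.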

Compound 4, concentration for 50% growth inhibition: 1880 nM
Estimate against measurement, compound 4: 9.0-fold (0.96 log units) above, outside the stated range (below it).
By their numbers in this assay, from the lowest: compound 4; then compounds 1 and 3 (each within the scatter of the next). At a limit, above all of these: compound 2.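

Against the two arms that stood level, 3-methoxybenzyl and (furan-2-yl)methyl, 4-isopropylphenyl on this nitrogen gives a large gain in growth inhibition in this assay (an 11-fold lower number from compound 3 to compound 4 (1.05 log units; beyond the scatter) and a 10-fold lower number from compound 1 to compound 4 (1.02 log units; beyond the scatter)). This shows that the position can do more than hold level or lose growth inhibition when the arm is changed in this way. The step from 2-methoxybenzyl (an at least 53-fold lower number from compound 2 to compound 4 (1.72 log units; beyond the scatter)) gives only a floor, as compound 2 stands at a limit of the assay: (the limit of > 100000 nM in this assay, at which 1 of the 4 values shown sits).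

Compound 4 loses the saturated chain carbon on the nitrogen and gains an isopropyl group in one change, and the compounds shown cannot separate the two. They also leave open how a plain phenyl group, or a phenyl group carrying an amine or a carboxylic acid in place of isopropyl, would fare here.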